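The source may report more compounds than this note shows. Statements on the series, on what has been measured and on what is new or still open speak of the compounds shown alone.

Measured compounds:
- compound 1 `O=C1/C(=C/c2cccnc2)CNC/C1=C\c1ccccc1F` gives 21000 nM in a functional assay on HepG2 cells (Homo sapiens) for cytotoxicity, read by MTT assay, with a stated time of 24 h; a higher number here means a weaker inhibitor, a lower number a stronger inhibitor
- compound 2 `O=C1/C(=C/c2cccnc2)CN(S(=O)(=O)c2ccccc2)C/C1=C\c1ccccc1F` gives 8210 nM in this assay
- compound 3 `O=C1/C(=C/c2ccncc2)CNC/C1=C\c1ccccc1C(F)(F)F` gives 6130 nM in this assay

Compound 1 and compound 2 share one core and differ in a single place: phenylsulfonyl in place of hydrogen on an amine nitrogen in a ring. That change gives a 2.6-fold lower number from compound 1 to compound 2 (0.41 log units; beyond the scatter), a step that lies beyond the scatter.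

Compound 3 carries a different core; how the core of compound 3 differs from the core of compound 1 is not broken down here. Compound 3 sits within the scatter of compound 2 in this assay and beyond the scatter of compound 1, so among the three measured compounds only the gap to compound 1 can be read as a difference.

Compound 4 `O=C1/C(=C/c2ccncc2)CN(S(=O)(=O)c2ccccc2)C/C1=C\c1ccccc1C(F)(F)F` is not yet measured. It stands to compound 3 as compound 2 stands to compound 1: phenylsulfonyl in place of hydrogen on an amine nitrogen in a ring. The place of the change is the same in both pairs, so this is the same change, made on the core of compound 3 instead of the core of compound 1.

Among the measured compounds shown here, the only guide to its size is the single measured instance of this change. Because compound 1 to compound 2 gave a 2.6-fold lower number from compound 1 to compound 2 (0.41 log units; beyond the scatter), a step of similar size is expected here, a 2.5-fold lower number from compound 3 to compound 4 (0.39 log units; beyond the scatter), with wider uncertainty since the core differs and the change has been seen only once. On that basis compound 4 is estimated at 2500 nM in this assay, with a likely range from 1100 nM to 6500 nM.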

Compound 4, half-maximal inhibitory concentration: 7020 nM
For compound 4 the middle estimate is 2.8-fold (0.45 log units) below the measured one; the whole stated range lies below it.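

In this assay, phenylsulfonyl in place of hydrogen on an amine nitrogen in a ring does not carry over at one size from core to core: the same change on two cores in this assay, a 2.6-fold lower number (0.41 log units; beyond the scatter) from compound 1 to compound 2 and a 1.1-fold higher number (0.06 log units; within the scatter) from compound 3 to compound 4, 2.9-fold (0.47 log units) apart, beyond the scatter of two such steps

On the core of compound 3 the step is a 1.1-fold higher number from compound 3 to compound 4 (0.06 log units; within the scatter), so the phenylsulfonyl group leaves that pair indistinguishable in this read-out, and the step seen on the core of compound 1 cannot be treated as a fixed increment for this series. These two pairs do not show which feature of the two cores goes with the gap, whether either step is the more typical one, or why the steps differ, and they say nothing about this change on any third core.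

The compounds shown leave open whether other groups on the same amine nitrogen, such as methylsulfonyl, acetyl or benzyl, also depend on the core in this way. Also open, on these data alone, is which part of the core difference matters, a question that pairs with and without phenylsulfonyl on cores differing in only one place could settle.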